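Aryl change from compound 3 to compound 4

The source may report more compounds than this note shows. Statements on the series, on what has been measured and on what is new or still open speak of the compounds shown alone.

Measured in a functional assay on PC-3 cells (Homo sapiens) for cytotoxicity, read by sulforhodamine B assay, with a stated time of 48 h; on this read-out lower numbers stand for stronger inhibition and higher numbers for weaker inhibition:
- compound 1 `C[C@H]1CC[C@@H]2[C@@H](OC(=O)[C@]23CC(c2ccc(Cl)cc2)=NO3)[C@]2(C)C(=O)C=C[C@@]12O` gives 49000 nM
- compound 2 `C[C@H]1CC[C@@H]2[C@@H](OC(=O)[C@]23CC(c2ccccc2Br)=NO3)[C@]2(C)C(=O)C=C[C@@]12O` gives 51000 nM
- compound 3 `C[C@H]1CC[C@@H]2[C@@H](OC(=O)[C@]23CC(c2ccc([N+](=O)[O-])cc2)=NO3)[C@]2(C)C(=O)C=C[C@@]12O` gives 12000 nM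

Compound 3 stands lowest of the three, with both gaps beyond the scatter. Compound 4 `C[C@H]1CC[C@@H]2[C@@H](OC(=O)[C@]23CC(c2ccccc2Cl)=NO3)[C@]2(C)C(=O)C=C[C@@]12O` differs from it as follows: 2-chlorophenyl in place of 4-nitrophenyl on a carbon with a double bond to nitrogen. In words, 2-chlorophenyl replaces 4-nitrophenyl on a carbon with a double bond to nitrogen. Among the measured compounds shown here, three measured steps bear on this. The two aryl halide compounds show a 1.0-fold higher number from compound 1 to compound 2 (0.02 log units; within the scatter), while the nitro compound departs from them in a 4.1-fold lower number from compound 1 to compound 3 (0.61 log units; beyond the scatter) and a 4.3-fold lower number from compound 2 to compound 3 (0.63 log units; beyond the scatter). Compound 4 is expected to sit with the two halogen-bearing compounds, so a modest rise in this assay is expected, about those two steps reversed. The expected step is a 4.0-fold higher number from compound 3 to compound 4 (0.60 log units; beyond the scatter). For compound 4 the estimated value is 48000 nM, with an expected range of 25000 nM to 90000 nM.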

Compound 4, half-maximal inhibitory concentration: 12000 nM
Compound 4: middle estimate off by 4.0-fold (0.60 log units), on the high side; the measured number lies below the stated range.
By their numbers in this assay, from the lowest: compounds 3 and 4 (each within the scatter of the next); then compounds 1 and 2 (each within the scatter of the next).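

In this assay, the nitro group is not needed to reach the low end of this small set: 2-chlorophenyl in place of 4-nitrophenyl leaves the number where it was (no change at the digits printed from compound 3 to compound 4 (within the scatter)). A halogen on the aryl ring does not by itself set the value, since chloro in place of bromo (a 4.3-fold lower number from compound 2 to compound 4 (0.63 log units; beyond the scatter)) and 2-chlorophenyl in place of 4-chlorophenyl (a 4.1-fold lower number from compound 1 to compound 4 (0.61 log units; beyond the scatter)) both separate compound 4 from the other halogen-bearing compounds.

From the compounds shown here alone, whether an amine or a carboxylic acid on the aryl ring would sit with compound 3 and compound 4 remains open. No supporting evidence accounts for the split among the halogen-bearing compounds.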